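The source may hold more compounds than are shown below. What is called first, only, known or untested is meant among the compounds shown, and "the series" means these compounds.

Compound 2 `CN1CC(=O)Nc2cnc(Nc3ccccc3)nc21` rests at the floor of a functional assay on BT-549 cells (Homo sapiens) for cytotoxicity, read by MTT assay, with a stated time of 48 h; on this read-out lower numbers stand for stronger inhibition and higher numbers for weaker inhibition: in this assay compound 2 gives > 100000 nM, which is a limit rather than a number. Compound 1 `COc1cccc(Nc2ncc3c(n2)NCC(=O)N3)c1` also gives only a limit in this assay, > 100000 nM. Compound 3 `CN1CC(=O)Nc2cnc(Nc3ccc(Cl)cc3)nc21` gives 91100 nM in this assay. Among the compounds with values here, the single measured step runs an at least 1.0-fold lower number from compound 2 to compound 3 (0.04 log units; that floor lies within the scatter) and stays within the scatter. Two of the three values sit at the limit of > 100000 nM in this assay, at which 2 of the 3 values shown sit. Compound 4 `COc1cccc(Nc2ncc3c(n2)N(C)CC(=O)N3)c1` differs from compound 2 by methoxy in place of hydrogen on an aromatic carbon. Within the data shown here, no measured step covers this change, and compound 1, which carries the same methoxy group, shows only a limit. Compound 4 is therefore expected to show no step beyond the scatter, a step that the limit leaves unreadable from compound 2 to compound 4, with an estimated value of 150000 nM and a range from 60000 nM to 500000 nM.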

Compound 4, half-maximal inhibitory concentration: > 100000 nM
Compound 4 was reported as a limit; the forecaster's own chance of this, stated with the estimate: 75%; the middle value does not contradict the limit.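

Within the data shown here, compound 4, like compound 1 and compound 2, gives only a limit in this assay and so no step from compound 1 or compound 2 to compound 4 can be read. The compounds shown leave open whether methoxy or the methyl on nitrogen changes cytotoxicity at all: the limit of > 100000 nM in this assay, at which 3 of the 4 values shown sit.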